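Trifluoromethyl to Nitro on the Aryl Ether Ring

The source may report more compounds than this note shows. Statements on the series, on what has been measured and on what is new or still open speak of the compounds shown alone.

Three thiosemicarbazide analogues have been examined in an assay on isolated protein for inhibition of A disintegrin and metalloproteinase with thrombospondin motifs 5 (Homo sapiens), read by spectrophotometry, with stated times of 10 min and 3 h; on this read-out lower numbers stand for stronger inhibition and higher numbers for weaker inhibition. Compound 1 `O=C(COc1cccc(Cl)c1)NNC(=S)NCc1ccc(-c2ccccc2)cc1` gives 2100 nM, compound 2 `O=C(COc1ccc(Cl)cc1)NNC(=S)NCc1cccnc1` gives 100000 nM, and compound 3 `O=C(COc1ccc(C(F)(F)F)cc1)NNC(=S)NCCCCC1CCCCC1` gives 540 nM. On these numbers compound 3 stands lowest of the three; its nearest neighbour is compound 1, whose number is higher by a margin beyond the scatter, and compound 2 lies far above both.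

The next compound, compound 4 `O=C(COc1ccc([N+](=O)[O-])cc1)NNC(=S)NCCCCC1CCCCC1`, keeps the whole of compound 3 except for one change: nitro in place of trifluoromethyl on an aromatic carbon. Going by the values given here, no pair among the three measured compounds differs in this single place, so nothing measured here shows what such a swap does.

Among the compounds with values here, with no comparable step to lean on, a change of modest size, if any, is expected in this assay, more likely towards a somewhat higher number than a lower one, and possibly none beyond the scatter. The step from compound 3 to compound 4 is therefore expected to be a 1.5-fold higher number from compound 3 to compound 4 (0.17 log units; within the scatter). In this assay compound 4 is expected to give about 800 nM, with a range from 250 nM to 3000 nM.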

Compound 4, half-maximal inhibitory concentration: 810 nM
Beside the measured number, compound 4's estimate is 1.0-fold (0.01 log units) below it, and the stated range covers the measured number.
By their numbers in this assay, from the lowest: compounds 3 and 4 (each within the scatter of the next); then compound 1; then compound 2.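

With the rest of compound 3 held fixed, nitro in place of trifluoromethyl gives a 1.5-fold higher number from compound 3 to compound 4 (0.18 log units; within the scatter) in this assay, the first step measured at this aromatic carbon, para to a large group. Within this series, this position therefore accepts both groups without a change beyond the scatter, although the group with no hydrogen-bond acceptors gives way to one with 2. The data do not show why the two groups give such similar numbers, and no supporting measurement bears on the result.

As far as these compounds go, whether an amine, a carboxylic acid or a nitrile on the same carbon would also stay within the scatter of compound 3 remains open. From the compounds shown here alone, it is also open whether the same swap would give a similar step with a different group at the other end of the shared core.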